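The source may hold more compounds than are shown below. What is called first, only, known or untested is meant among the compounds shown, and "the series" means these compounds.

All of the compounds share one core and differ only in a single group on an aromatic carbon. In a functional assay on MCF7 cells (Homo sapiens) for inhibition, read by MTT assay, with a stated time of 72 h (a higher number here means a weaker inhibitor, a lower number a stronger inhibitor), compound 1 (`C=C(Br)C(=O)Nc1cccc(/C=C/C(=O)Nc2ccc(Cl)cc2)c1`) gives 11000 nM, compound 2 (`C=C(Br)C(=O)Nc1cccc(/C=C/C(=O)Nc2ccc(C)cc2)c1`) gives 2500 nM and compound 3 (`C=C(Br)C(=O)Nc1cccc(/C=C/C(=O)Nc2ccc(OCC)cc2)c1`) gives 5500 nM. Swapping chloro for ethoxy gives a 2.0-fold lower number from compound 1 to compound 3 (0.30 log units; within the scatter), so compound 3 cannot be told apart from compound 1. Swapping methyl for ethoxy gives a 2.2-fold higher number from compound 2 to compound 3 (0.34 log units; beyond the scatter), a modest separation from compound 2.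

Compound 4 (`C=C(Br)C(=O)Nc1cccc(/C=C/C(=O)Nc2ccc(SC(F)(F)F)cc2)c1`) has (trifluoromethyl)sulfanyl in place of ethoxy on an aromatic carbon. The three measured swaps all bear on this change, although none of them involves the entering group. Among the measured compounds shown here, the largest is the modest 4.4-fold lower number from compound 1 to compound 2 (0.64 log units; beyond the scatter), so these swaps offer no precedent for a large move, and they do not settle a direction. No change beyond the scatter is therefore expected, and the estimated step is a 1.1-fold higher number from compound 3 to compound 4 (0.04 log units; within the scatter). For compound 4, the estimated value is 6000 nM, with an expected range of 2200 nM to 16000 nM.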

Compound 4, half-maximal inhibitory concentration: 30100 nM
Compound 4: the middle estimate sits 5.0-fold (0.70 log units) below what was measured; measured number above the stated range.
By their numbers in this assay, from the lowest: compound 2; then compounds 3 and 1 (each within the scatter of the next); then compound 4.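

In this assay, this position can shift the number further than the earlier swaps suggested, and the change to (trifluoromethyl)sulfanyl moves it upward against every other group: a 5.5-fold higher number from compound 3 to compound 4 (0.74 log units; beyond the scatter), a 2.7-fold higher number from compound 1 to compound 4 (0.44 log units; beyond the scatter) and a 12-fold higher number from compound 2 to compound 4 (1.08 log units; beyond the scatter). Among the compounds shown here, the last of these is the only large step in the set, and since all three lie beyond the scatter, compound 4 is the weakest inhibitor of the four. Nothing in the available data gives a reason for this loss.

Whether the sulfur or the fluorines account for the change stays open, and a methylsulfanyl or a trifluoromethyl group at the same place would help separate the two. As far as these compounds go, how an amine or a carboxylic acid would compare with these four groups also remains unknown.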